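Halogen exchange on the aryl ring: compound 3 to compound 4

The compounds below may be only part of what the source reports. "The series", "measured", "known", "first", "only" and "open" are said of these compounds alone.

Measured compounds:
compound 1, `O=C(CSc1nnnn1-c1ccccc1)N/N=c1/scc(-c2ccc(Br)cc2)n1-c1ccccc1`, gives 58.6% in a functional assay on C6 cells (Rattus norvegicus) for cytotoxicity, read by MTT assay, with a stated time of 24 h, tested at 12 ug/mL; a higher number here means a weaker effect of the compound at the concentration tested, a lower number a stronger effect
compound 2, `Cc1ccc(-c2cs/c(=N/NC(=O)CSc3nncn3C)n2-c2ccccc2)cc1`, gives 72% in this assay
compound 3, `O=C(CSc1ncccn1)N/N=c1/scc(-c2ccc(Br)cc2)n1-c1ccccc1`, gives 72.1% in this assay

Compound 3 stands at the upper end of the three numbers in this assay. Among the measured compounds shown here, its separation from compound 1 lies beyond the scatter, as the single measured step of a number 13.5 percentage points higher from compound 1 to compound 3 (beyond the scatter) shows; its separation from compound 2 lies within the scatter, so no order between compound 3 and compound 2 can be read.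

Compound 4, `O=C(CSc1ncccn1)N/N=c1/scc(-c2ccc(F)cc2)n1-c1ccccc1`, is not yet measured. It differs from compound 3 in one place: fluoro in place of bromo on an aromatic carbon. For the measured compounds named here, no measured step touches this position. Going by the values given here, the one step in hand, a number 13.5 percentage points higher from compound 1 to compound 3 (beyond the scatter), concerns the group on the sulfur, not the halogen on the aryl ring, so it does not bear on the change to compound 4. Compound 2 carries a methyl at this position, but it also differs at the sulfur, so only its value beside that of compound 3 can be stated, and the two lie within the scatter.

Among the compounds with values here, with no step to lean on, the expected step of a number 2.1 percentage points lower from compound 3 to compound 4 (within the scatter) is none beyond the scatter. Compound 4 is therefore estimated at 70% in this assay, in the range 55% to 85%.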

Compound 4, a percentage reported as activity, at one concentration (the size of the read-out at that concentration, not a potency): 77.4%
Compound 4: middle estimate off by 7.4 percentage points, on the low side, within the range that was stated.
By their numbers in this assay, from the lowest: compound 1; then compounds 2, 3 and 4 (each within the scatter of the next).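

In this assay, among the compounds shown here, the change from 4-bromophenyl to 4-fluorophenyl gives the first direct reading at this position, with the pyrimidin-2-yl on the sulfur held constant: a number 5.3 percentage points higher from compound 3 to compound 4 (within the scatter) is the step for fluoro in place of bromo on an aromatic carbon. For the compounds shown here, at this position and with this sulfur group, the two halogens therefore cannot be told apart in this read-out, while the one step beyond the scatter, a number 13.5 percentage points higher from compound 1 to compound 3 (beyond the scatter) and so a change at the sulfur group, remains the only sign of a real difference. Nothing at hand bears on the reason for either reading.

The compounds shown leave open whether the same halogen exchange would read alike with 1-phenyl-1H-tetrazol-5-yl on the sulfur, since each halogen pairing here rests on the single pyrimidin-2-yl background. They also leave open whether a group of another kind at this aromatic carbon, such as an amine, a carboxylic acid or a longer alkoxy chain, would give a step beyond the scatter in this assay where the exchange of one halogen for another does not.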